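Amino in place of hydrogen on the trimethoxyphenyl oxadiazole

The compounds below may be only part of what the source reports. "The series", "measured", "known", "first", "only" and "open" are said of these compounds alone.

The measured compounds:
compound 1 `Clc1ccc(-c2noc(Cc3c[nH]c4ccccc34)n2)cc1` > 50000 nM
compound 2 `COc1ccc(Br)c(-c2nc(Cc3c[nH]c4ccccc34)no2)c1` 6900 nM
compound 3 `COc1cc(-c2noc(-c3ccccc3)n2)cc(OC)c1OC` > 50000 nM

The account follows compound 3 `COc1cc(-c2noc(-c3ccccc3)n2)cc(OC)c1OC` in a functional assay on cells (Splenocyte, Mus musculus, strain BALB/c) for inhibition, read by scintillation counting and thymidine incorporation, with stated times of 48 h and 8 h; a higher number here means a weaker inhibitor, a lower number a stronger inhibitor. Compound 3 gives only a limit there, > 50000 nM, and not a number. That limit is the limit of > 50000 nM in this assay, at which 2 of the 3 values shown sit, so compound 3 stands at the weak end of what has been measured and no finer ranking of it is possible. Compound 1 also returns only a limit, > 50000 nM. Going by the values given here, compound 2 alone gives a number, 6900 nM, but it differs from compound 3 in more than one place, so no step between them can be read.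

Compound 4 `COc1cc(-c2noc(-c3ccc(N)cc3)n2)cc(OC)c1OC` is not yet measured. It differs from compound 3 by amino in place of hydrogen on an aromatic carbon. Among the compounds with values here, no measured pair shows what this change does, and since compound 3 sits at a limit, only a gain can show. Compound 4 is expected to remain weak, with a step of an at least 1.2-fold lower number from compound 3 to compound 4 (0.09 log units; that floor lies within the scatter) that is estimated to be small, most likely within the scatter, and a fair chance of another limit. The estimate for compound 4 is 40000 nM, in the range 10000 nM to 50000 nM.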

Compound 4, half-maximal inhibitory concentration: 1700 nM
The estimate for compound 4 lay 24-fold (1.37 log units) above the measured number, and the stated range ends above it.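

In this assay the change of phenyl to 4-aminophenyl gives an at least 29-fold lower number from compound 3 to compound 4 (1.46 log units; beyond the scatter), the only step among the compounds shown that can be read. It shows that this place on the core is not silent: a single amino group in place of hydrogen brings the trimethoxyphenyl compound off the limit to a real number. The true size of the gain stays unknown, since only a floor can be given when the starting compound stands at a limit: the limit of > 50000 nM in this assay, at which 2 of the 4 values shown sit.

The compounds shown leave open whether the amino group itself is needed, or whether a hydroxyl, a methylamino or an acetamide in the same place would do as much. They also leave open whether amino in place of the chlorine of compound 1 would bring that compound off its limit.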